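This account rests on a few compounds, and the source may have more. Where it says the series, first, only, none or still open, it means among the compounds named here.

Working notes on the series.

Compound 3 `CC1(C)[C@H]2CC[C@]1(C)N(Cc1cn(-c3ccc(C#N)cc3)nn1)C(=O)C2` gives the lowest number of the three measured in a functional assay on HepG2 cells (Homo sapiens) for inhibition, read by MTT assay, with a stated time of 24 h (a higher number here means a weaker inhibitor, a lower number a stronger inhibitor), at 50 nM. Compound 1 `COc1ccccc1-n1cc(CN2C(=O)C[C@@H]3CC[C@@]2(C)C3(C)C)nn1` gives 110 nM in this assay, and compound 2 `Cc1ccc(-n2cc(CN3C(=O)C[C@@H]4CC[C@@]3(C)C4(C)C)nn2)cc1` gives 480 nM. The step of a 2.2-fold lower number from compound 1 to compound 3 (0.34 log units; beyond the scatter) and the step of a 9.6-fold lower number from compound 2 to compound 3 (0.98 log units; beyond the scatter) both place compound 3 below its neighbours beyond the scatter, while the step of a 4.4-fold higher number from compound 1 to compound 2 (0.64 log units; beyond the scatter) separates the two aryl groups that lack the cyano.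

Compound 4 `CC1(C)[C@H]2CC[C@]1(C)N(Cc1cn(-c3ccccc3F)nn1)C(=O)C2` differs from compound 3 as follows: 2-fluorophenyl in place of 4-cyanophenyl on an aromatic nitrogen. The most relevant comparison is compound 1, which also carries a substituted phenyl without the cyano at this nitrogen and gives 110 nM; the removal of the cyano in the step of a 9.6-fold lower number from compound 2 to compound 3 (0.98 log units; beyond the scatter) was the largest single step recorded. Among the compounds with values here, a weaker result than compound 3 is therefore expected, in the region of compound 1 rather than compound 2, since no step for a fluoro group is known.

For compound 4 the expected value in this assay is 150 nM, within 60 nM to 400 nM, corresponding to an estimated step of a 3.0-fold higher number from compound 3 to compound 4 (0.48 log units; beyond the scatter).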

Compound 4, half-maximal inhibitory concentration: 60 nM
The estimate for compound 4 lay 2.5-fold (0.40 log units) above the measured number; the measured number falls inside the stated range.
By their numbers in this assay, from the lowest: compounds 3, 4 and 1 (each within the scatter of the next, the first and the last beyond it); then compound 2.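

In this assay, the step of a 1.2-fold higher number from compound 3 to compound 4 (0.08 log units; within the scatter) shows that a phenyl on the aromatic nitrogen without the nitrile can match 4-cyanophenyl, so the low numbers in this set are not tied to that group. Within the data shown here, the step of a 1.8-fold lower number from compound 1 to compound 4 (0.26 log units; within the scatter) also leaves 2-fluorophenyl level with 2-methoxyphenyl, while the step of an 8.0-fold lower number from compound 2 to compound 4 (0.90 log units; beyond the scatter) keeps 4-methylphenyl as the one aryl group set apart from the others. Nothing available explains these differences.

The compounds shown do not separate the place of a substituent on the phenyl ring from its identity: 4-methylphenyl has no counterpart with the methyl elsewhere on the ring, and 2-fluorophenyl none with the fluoro elsewhere. Going by these compounds, how an unsubstituted phenyl, or a phenyl carrying an amine or a carboxylic acid, would read in this assay remains open.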